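Arylsulfonyl in place of aryl on the piperazine nitrogen

This account rests on a few compounds, and the source may have more. Where it says the series, first, only, none or still open, it means among the compounds named here.

Three measured compounds share one core and differ only in the group on the amine nitrogen in the ring. Compound 1 `O=C(/C=C/c1ccccc1)c1ccc(N2CCN(c3ccc(Cl)c(Cl)c3)CC2)cc1` gives 13.4% in a functional assay on the whole organism (strain Kunming) for inhibition, with Mus musculus as the target, with a stated time of 1 h, at a dose of 40 mg/kg by the oral route; a lower number here means less inhibition, a higher number more inhibition at the dose given (going by the name of the read-out). Compound 2 `COc1cccc(N2CCN(c3ccc(C(=O)/C=C/c4ccccc4)cc3)CC2)c1` gives 16%, and compound 3 `O=C(/C=C/c1ccccc1)c1ccc(N2CCN(c3cccc(C(F)(F)F)c3)CC2)cc1` gives 25%. Compound 3 has the highest of the three numbers, but only its gap to compound 1 is beyond the scatter, seen in a number 11.6 percentage points higher from compound 1 to compound 3 (beyond the scatter); the gap to compound 2, a number 9 percentage points higher from compound 2 to compound 3 (within the scatter), is within it, as is a number 2.6 percentage points higher from compound 1 to compound 2 (within the scatter).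

Compound 4 `O=C(/C=C/c1ccccc1)c1ccc(N2CCN(S(=O)(=O)c3ccc(Br)cc3)CC2)cc1` has not yet been measured. It differs from compound 3 in this way: (4-bromophenyl)sulfonyl in place of 3-(trifluoromethyl)phenyl on an amine nitrogen in a ring. Within the data shown here, none of the measured steps bears directly on this change: all three swap one substituted phenyl for another on the same nitrogen, while here the phenyl itself gives way to a (4-bromophenyl)sulfonyl. The measured values all lie in a narrow band, so no large movement in either direction is grounded in the data. Compound 4 is therefore expected to show no step beyond the scatter, a number 7 percentage points lower from compound 3 to compound 4 (within the scatter), and its inhibition is estimated at 18%, with a range from 6% to 32%.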

Compound 4, a percentage reported as inhibition, in the whole organism at one dose (the size of the read-out at that dose, not a potency): 47.4%
The estimate for compound 4 lay 29.4 percentage points below the measured number; measured number above the stated range.
By their numbers in this assay, from the lowest: compounds 1, 2 and 3 (each within the scatter of the next, the first and the last beyond it); then compound 4.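

On the amine nitrogen in the ring, putting (4-bromophenyl)sulfonyl in place of a substituted phenyl moves the read-out in this assay further than any exchange among the phenyl groups did. Against each of the three earlier compounds the change gives a step beyond the scatter: a number 22.4 percentage points higher from compound 3 to compound 4 (beyond the scatter) for the exchange of 3-(trifluoromethyl)phenyl, a number 31.4 percentage points higher from compound 2 to compound 4 (beyond the scatter) for the exchange of 3-methoxyphenyl and a number 34 percentage points higher from compound 1 to compound 4 (beyond the scatter) for the exchange of 3,4-dichlorophenyl, so the new compound stands apart whichever phenyl group it is compared with. The position therefore responds far more to this change than the swaps of one substituted phenyl for another could show, yet nothing at hand accounts for the size of these steps.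

The compounds shown do not separate the sulfonyl link from the bromine, since a plain phenylsulfonyl, a 4-chlorophenylsulfonyl or a methanesulfonyl on the same nitrogen would be needed to tell which part carries the step. A benzoyl there would likewise show whether the sulfonyl itself matters, and the whole comparison rests on one dose and one time point.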